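Cytotoxicity of a hydrazide and its benzylamide relative

This account rests on a few compounds, and the source may have more. Where it says the series, first, only, none or still open, it means among the compounds named here.

Measured compounds:
- compound 1 `COc1ccc(CNC(=O)c2nc(C(C)(C)NC(=O)OCc3ccccc3)nc(O)c2O)cc1` gives 164000 nM in an ADME assay on C8166 cells (Homo sapiens) for cytotoxicity, read by MTT assay, with a stated time of 3 days; on this read-out lower numbers stand for higher toxicity in this test and higher numbers for lower toxicity in this test
- compound 2 `CC(C)(NC(=O)OCc1ccccc1)c1nc(O)c(O)c(C(=O)NN)n1` gives > 500000 nM in this assay

For compound 2 the number shown in this assay is only a limit of the assay and not a measured value. Compound 2 therefore stands at the top of what this test can report, as stated in the limit of > 500000 nM in this assay, at which 1 of the 2 values shown sits. Compound 3 `CC(C)(NC(=O)OCc1ccccc1)c1nc(O)c(O)c(C(=O)NCc2ccc(C(F)(F)F)cc2)n1` has not yet been measured in this assay; it differs from compound 2 in one place: 4-(trifluoromethyl)benzyl in place of amino on an amide-type nitrogen.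

Going by the values given here, only one measured step bears on this change. Going an at least 3.0-fold higher number from compound 1 to compound 2 (0.48 log units; beyond the scatter), the number rose at least modestly, beyond the scatter, when amino replaced the 4-methoxybenzyl group. The step from compound 2 to compound 3 runs the other way, restoring a benzyl-type group on the same amide nitrogen, now carrying trifluoromethyl rather than methoxy. Compound 3 is therefore expected to come back down toward the level of compound 1, a change of an at least 3.3-fold lower number from compound 2 to compound 3 (0.52 log units; beyond the scatter), meaning higher toxicity in this assay. The expected value for compound 3 in this assay is 150000 nM, with a range from 60000 nM to 400000 nM.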

Compound 3, half-maximal cytotoxic concentration: 58100 nM
Estimate against measurement, compound 3: 2.6-fold (0.41 log units) above, outside the stated range (below it).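

In this assay, 4-(trifluoromethyl)benzyl in place of amino on the amide-type nitrogen gave an at least 8.6-fold lower number from compound 2 to compound 3 (0.93 log units; beyond the scatter), so the link between a substituted benzyl group on this nitrogen and a lower number now rests on two groups, 4-methoxybenzyl and 4-(trifluoromethyl)benzyl, rather than on one. The size of that step is itself bounded, since compound 2 is held only as a limit of the assay and not as a measured value: the limit of > 500000 nM in this assay, at which 1 of the 3 values shown sits. Going by these compounds alone, what the earlier compounds could not show is that the group on the aromatic ring also counts, for trifluoromethyl in place of methoxy on an aromatic carbon gave a 2.8-fold lower number from compound 1 to compound 3 (0.45 log units; beyond the scatter), so the two benzyl relatives do not sit at one level.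

The compounds shown leave open whether this lower number is particular to trifluoromethyl or would also appear with another ring group, such as a chlorine atom or a nitrile. They also leave open where an unsubstituted benzyl group or a plain butyl chain on the same nitrogen would fall relative to these values.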